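Amine tail variation on the shared core, toward compound 4

The source may report more compounds than this note shows. Statements on the series, on what has been measured and on what is new or still open speak of the compounds shown alone.

Compound 3 `CN(C)CCCOc1ccc(-c2nc3ccc(Oc4ccc(Cl)cc4)cc3o2)cc1` gives 4.9% in an assay on isolated protein for inhibition of advanced glycosylation end product-specific receptor (Homo sapiens), read by FRET, with stated times of 30 min and 1 h, tested at 4 uM (on this read-out higher numbers stand for more inhibition at the one concentration tested (going by the name of the read-out) and lower numbers for less inhibition), the lowest of the two numbers in hand; the nearest is compound 2 `CCN1CCC(Oc2ccc(-c3nc4ccc(Oc5ccc(Cl)cc5)cc4o3)cc2)CC1` at 15.3%. Compound 1 `Clc1ccc(Oc2ccc3nc(-c4ccc(OCC5CCNCC5)cc4)oc3c2)cc1` is reported in this assay only as "not active" (no number reported), with no number. Compound 4 `Clc1ccc(Oc2ccc3nc(-c4ccc(OCCCN5CCCCC5)cc4)oc3c2)cc1` differs from compound 3 by piperidin-1-yl in place of dimethylamino on a saturated chain carbon, three bonds along the chain from an oxygen on an aromatic ring. Among the measured compounds shown here, the one step that bears on this, a number 10.4 percentage points lower from compound 2 to compound 3 (beyond the scatter), also swapped a cyclic amine for dimethylamino and went down modestly, so restoring a ring might recover something; compound 1, carrying a different ring, goes against any such pattern. The expected step of a number 5.1 percentage points higher from compound 3 to compound 4 (within the scatter) is therefore small, likely within the scatter. Compound 4 is estimated at 10%, in the range 0% to 22%.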

Compound 4, a percentage reported as inhibition, at one concentration (the size of the read-out at that concentration, not a potency): 2.2%
Compound 4: the middle estimate sits 7.8 percentage points above what was measured, and the stated range covers the measured number.
By their numbers in this assay, from the lowest: compounds 4 and 3 (each within the scatter of the next); then compound 2.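

In this assay, piperidin-1-yl in place of dimethylamino at this position gives a number 2.7 percentage points lower from compound 3 to compound 4 (within the scatter), so closing this amine into a ring does not by itself recover inhibition. The step of a number 13.1 percentage points lower from compound 2 to compound 4 (beyond the scatter) runs the same way as a number 10.4 percentage points lower from compound 2 to compound 3 (beyond the scatter), placing both 3-substituted propyl amines apart from 1-ethylpiperidin-4-yl, though compound 1, also carrying a ring amine, gives "not active" (no number reported) and goes against any link between that ring type and activity. Nothing on hand explains these differences.

Still open, as far as these compounds go, is how a morpholin-4-yl group on the same propyl chain would read, or a longer chain ending in piperidin-1-yl.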